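This account rests on a few compounds, and the source may have more. Where it says the series, first, only, none or still open, it means among the compounds named here.

Compound 2 `O=C(O)c1ccc(C(=O)/C(=C\c2ccc([N+](=O)[O-])cc2F)SCc2ccc(Br)cc2)cc1` stands in a physicochemical assay for solubility (a lower number here means a less soluble compound, a higher number a more soluble compound), at a limit rather than a number, < 1000 ug/mL. Compound 1 `O=C(O)c1ccc(C(=O)/C(=C\c2ccc(O)c(Br)c2)SCc2ccc(Br)cc2)cc1` likewise gives only a limit in this assay, < 1000 ug/mL. The step that the two limits leave unreadable from compound 1 to compound 2 therefore cannot be read, since the limit of < 1000 ug/mL in this assay, at which 2 of the 2 values shown sit, leaves both ends open. Compound 3 `COc1cc(/C=C(/SCc2ccc(Br)cc2)C(=O)c2ccc(C(=O)O)cc2)ccc1F` differs from compound 2 by 4-fluoro-3-methoxyphenyl in place of 2-fluoro-4-nitrophenyl on a double-bonded chain carbon bound to a double-bonded chain carbon. No measured step bears on this change, so neither direction nor size of the change in this assay can be taken from the shown pairs. Compound 3 is expected to give in this assay an estimated 300 ug/mL, between 50 ug/mL and 1000 ug/mL. The expected step that the limit leaves unreadable from compound 2 to compound 3 is a guess without a measured precedent.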

Compound 3, solubility: < 1000 ug/mL
Compound 3: only a limit was reported; the forecaster's own chance of this, stated with the estimate: 60%; the middle value does not contradict the limit.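

In this assay compound 3 also gives only a limit, < 1000 ug/mL. The steps to it from compound 1 and compound 2 therefore cannot be read: the limit of < 1000 ug/mL in this assay, at which 3 of the 3 values shown sit. The compounds shown leave open whether compound 1, compound 2 and compound 3 differ in solubility at all.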